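From 2-fluorophenyl to 3-chlorophenyl: an expected tolerance

A few compounds are considered here, and "the series" means these few. Any claim that something is new, unique, unknown or untested is made for them only; others in the source may bear on it.

Compound 1 `COc1cc(-c2ccc(C#N)cc2)ccc1Oc1cc(N)nc(Nc2ccc(C#N)cc2)n1`: 120000 nM
Compound 2 `Cc1cc(-c2ccccc2F)cc(C)c1Oc1cc(N)nc(Nc2ccc(C#N)cc2)n1`: 29300 nM

In a toxicity assay on MT4 cells (Homo sapiens) for cytotoxicity, read by MTT assay (a higher number here means that more compound is tolerated, a lower number that less compound is tolerated), compound 2 stands lowest of the two measured compounds at 29300 nM. Compound 1, at 120000 nM, lies above it by a gap beyond the usual scatter. That gap cannot be credited to any single group, since the two compounds differ in more than one place.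

Compound 3 `Cc1cc(-c2cccc(Cl)c2)cc(C)c1Oc1cc(N)nc(Nc2ccc(C#N)cc2)n1` has not yet been measured. It differs from compound 2 in one place only: 3-chlorophenyl in place of 2-fluorophenyl on an aromatic carbon. Here 3-chlorophenyl takes the place of 2-fluorophenyl on an aromatic carbon, meta to two methyl groups and para to a large group.

Going by the values given here, no measured pair shows what a single change of this kind does, so the expectation rests on compound 2 alone. No step beyond the scatter is expected in this assay, and compound 3 should stay close to compound 2 at 29300 nM. The estimated change is a 1.2-fold lower number from compound 2 to compound 3 (0.07 log units; within the scatter). For compound 3 the expected value is 25000 nM, with an estimated range from 9000 nM to 70000 nM.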

Compound 3, half-maximal cytotoxic concentration: 22300 nM
Compound 3: the middle estimate sits 1.1-fold (0.05 log units) above what was measured; the range from low to high includes it.
By their numbers in this assay, from the lowest: compounds 3 and 2 (each within the scatter of the next); then compound 1.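

In this assay, going by these compounds alone, putting 3-chlorophenyl in place of 2-fluorophenyl gives a 1.3-fold lower number from compound 2 to compound 3 (0.12 log units; within the scatter), the first comparison that differs in one place only. On this aromatic carbon, meta to two methyl groups and para to a large group, the read-out does not tell these two groups apart, although the halogen and its place on the phenyl ring both differ between them. No measurement is at hand that could explain why the two compounds read alike.

Because the halogen and its place change together in this single pair, the compounds shown cannot separate what each change does alone, and a 3-fluorophenyl or 2-chlorophenyl group would be needed to pull the two apart. Going by these compounds, it also remains open whether this tolerance holds only among halogen-bearing phenyl groups or extends to a phenyl ring carrying an amine or a carboxylic acid at this position, since both groups compared here have no hydrogen-bond donors and no net charge.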